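The source may report more compounds than this note shows. Statements on the series, on what has been measured and on what is new or still open speak of the compounds shown alone.

In an in vitro functional assay on HEK ts201 cells for antagonist activity at Neuronal acetylcholine receptor; alpha4/beta2 (Homo sapiens), read by fluorescence and calcium flux (a higher number here means a weaker inhibitor, a lower number a stronger inhibitor), three compounds have been measured so far. Compound 1 `O=C(OCC1=CCCN(CCCc2ccccc2)C1)c1ccccc1N1C(=O)CC(Cc2ccccc2)C1=O` gives 5130 nM. Compound 2 `CC1CC(=O)N(c2ccccc2C(=O)OCC2CCCN(CCCCOc3ccc(Cl)c(Cl)c3)C2)C1=O` gives 12300 nM. Compound 3 `O=C(NCc1ccccc1-c1ccccc1)C1CCCN(CCCc2ccccc2)C1` gives 16600 nM. Among these, compound 2 stands with the second-highest number: its nearest neighbour is compound 3, whose number is somewhat higher but within the usual scatter of such measurements, so no order between compound 2 and compound 3 can be claimed; its furthest neighbour is compound 1, whose lower number lies beyond the scatter, so compound 1 is the stronger inhibitor of the two.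

Compound 4 `CC1CC(=O)N(c2ccccc2C(=O)OCC2CCCN(CCCCCCc3ccccc3)C2)C1=O` has not yet been measured. It differs from compound 2 in one place: phenethyl in place of 3,4-dichlorophenoxy on a saturated chain carbon, four bonds along the chain from an amine nitrogen in a ring. Going by the values given here, no pair of measured compounds differs in exactly this way, so the size of the step has to be estimated rather than read from a measured example. Compound 1, which also carries a phenyl-ended chain on the ring amine nitrogen, gives 5130 nM, but it differs from compound 2 in several places at once, so it offers only a loose hint. The step from compound 2 to compound 4 is expected to be a 1.4-fold lower number from compound 2 to compound 4 (0.16 log units; within the scatter), a modest move toward a lower number that may well stay within the scatter. Compound 4 is therefore estimated to give about 8500 nM in this assay, with a range from 3000 nM to 25000 nM.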

Compound 4, half-maximal inhibitory concentration: 29500 nM
Compound 4: the middle estimate sits 3.5-fold (0.54 log units) below what was measured; the whole stated range lies below it.
By their numbers in this assay, from the lowest: compound 1; then compounds 2, 3 and 4 (each within the scatter of the next, the first and the last beyond it).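

In this assay, the change at this position gives a 2.4-fold higher number from compound 2 to compound 4 (0.38 log units; beyond the scatter) and so makes compound 4 the weaker inhibitor of this pair. The earlier compounds shown here could not show this, as no two of them differed in one place only; here, a single change on a saturated chain carbon, four bonds along the chain from an amine nitrogen in a ring, moves the number beyond the scatter. The size of the end group hardly changes, since 3,4-dichlorophenoxy has 9 heavy atoms and phenethyl 8, each with one six-membered aromatic ring of carbon only, while the oxygen and both chlorines leave together, and no measurement offered here explains why the number rises.

Because the oxygen and the chlorines go in the same step, this pair cannot tell which of them matters, or whether both do. On these data alone, the plain phenoxy group and the 3,4-dichlorophenethyl group would each change only part of this difference, and they remain open at this position, as does a longer chain carrying either end group.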